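Swapping methoxy for fluoro on the quinoline pendant ring

The source may hold more compounds than are shown below. What is called first, only, known or untested is meant among the compounds shown, and "the series" means these compounds.

Measured compounds:
- compound 1, `COc1ccc(-c2ccc3c(NCCCNCc4cccc(OC)c4O)ccnc3c2)cc1`, 9.47
- compound 2, `COc1cccc(CNCCCNc2ccnc3cc(-c4ccc(F)cc4)ccc23)c1O`, 9.47
- compound 3, `COc1ccc(Oc2ccc3c(NCCCNCc4cc(F)ccc4OC)ccnc3c2)cc1`, 9.28

In a physicochemical assay for acid dissociation, compound 1 gives 9.47 and compound 2 gives 9.47. The change between them, (fluoro in place of methoxy on an aromatic carbon), gave a step of no change at the digits printed from compound 1 to compound 2 (within the scatter). Compound 3 carries a different core; the difference between its core and that of compound 1 is not broken down here. In this assay compound 3 gives 9.28, which sits within the scatter of the values of compound 1 and compound 2.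

Compound 4, `COc1ccc(F)cc1CNCCCNc1ccnc2cc(Oc3ccc(F)cc3)ccc12`, has not yet been measured. It differs from compound 3 by fluoro in place of methoxy on an aromatic carbon, the same change that led from compound 1 to compound 2, on an aromatic carbon para to a large group in both cases. Since compound 1 to compound 2 showed no change at the digits printed from compound 1 to compound 2 (within the scatter), the step from compound 3 to compound 4 is expected to be no change at the digits printed from compound 3 to compound 4 (within the scatter). Compound 4 is therefore estimated at 9.28, between 9 and 9.58.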

Compound 4, acid dissociation constant: 9.28
For compound 4 middle estimate and measured number coincide at the digits printed; low and high end bracket the measured number.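

In this assay, putting fluoro in place of methoxy on an aromatic carbon gave no change at the digits printed from compound 3 to compound 4 (within the scatter), just as the same change had given no change at the digits printed from compound 1 to compound 2 (within the scatter) on the core of compound 1. So in the two pairs available, 4-methoxyphenyl to 4-fluorophenyl and 4-methoxyphenoxy to 4-fluorophenoxy, the change carried over from one core to another without moving the number beyond the scatter, but two pairs show only that it held on these two cores, not that it would hold on every core in the series. Nothing measured here says why the number stays put.

The compounds shown leave open whether a group such as chloro, an amine or a carboxylic acid, placed on an aromatic carbon para to a large group, would also leave this assay unmoved. For the compounds shown here, they also leave open whether the swap would still make no difference on a compound with a longer chain.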